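From compound 3 to compound 4: working notes

This account rests on a few compounds, and the source may have more. Where it says the series, first, only, none or still open, it means among the compounds named here.

Compound 1 `COc1cc(OC)c(-c2coc3cc(OCc4ccccc4)ccc3c2=O)cc1OC`: 6750 nM
Compound 2 `COc1cc(OC)c(-c2coc3cc(OCc4ccc(F)cc4)ccc3c2=O)cc1OC`: 3200 nM
Compound 3 `COc1cc(OC)c(-c2coc3cc(OCc4ccc([N+](=O)[O-])cc4)ccc3c2=O)cc1OC`: 9400 nM

All three values come from a functional assay on U-251 cells (Homo sapiens) for antiproliferative activity, read by MTT assay, with a stated time of 24 h; a higher number here means a weaker inhibitor, a lower number a stronger inhibitor. Compound 3 has the highest number of the three, but only a 2.9-fold higher number from compound 2 to compound 3 (0.47 log units; beyond the scatter) lies beyond the scatter, while a 1.4-fold higher number from compound 1 to compound 3 (0.14 log units; within the scatter) does not.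

Compound 4 `COc1cc(OC)c(-c2coc3cc(OCc4cccc(Cl)c4)ccc3c2=O)cc1OC` follows from compound 3 by 3-chlorophenyl in place of 4-nitrophenyl on a saturated chain carbon bound to an oxygen on an aromatic ring. For the measured compounds named here, no measured compound carries a 3-chlorophenyl group, so the guide is the size of the other steps: a 2.1-fold lower number from compound 1 to compound 2 (0.32 log units; beyond the scatter) and the two above. All are modest or smaller, so only a small move toward a lower number is expected. The estimated change is a 1.7-fold lower number from compound 3 to compound 4 (0.23 log units; within the scatter). For compound 4 the estimated value is 5500 nM, with an expected range of 2500 nM to 12000 nM.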

Compound 4, half-maximal inhibitory concentration: > 10000 nM
Compound 4: a limit, no number; the forecaster's own chance of this, stated with the estimate: 3%; middle value at least 1.8-fold (0.25 log units) from the limit.
By their numbers in this assay, from the lowest: compound 2; then compounds 1 and 3 (each within the scatter of the next). At a limit, above all of these: compound 4.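

In this assay compound 4 gives > 10000 nM, which is a limit and not a number. Only an at least 3.1-fold higher number from compound 2 to compound 4 (0.49 log units; beyond the scatter) lies clearly beyond the scatter, so 3-chlorobenzyl does not keep the lower number seen with 4-fluorobenzyl at this position. The floors of an at least 1.4-fold higher number from compound 1 to compound 4 (0.17 log units; that floor lies within the scatter) and an at least 1.0-fold higher number from compound 3 to compound 4 (0.02 log units; that floor lies within the scatter) lie within the scatter, so the size of these two changes stays unfixed.

The compounds shown leave open whether the chloro group itself or its place on the ring sets this result. Also open, as far as these compounds go, is how an amine on this ring, or a longer chain in place of the saturated chain carbon, would read.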